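The source may report more compounds than this note shows. Statements on the series, on what has been measured and on what is new or still open speak of the compounds shown alone.

Compound 1 `CCOC(=O)c1ccc(Oc2ccc(OC)c(OC)c2)cc1`: > 20000 nM
Compound 2 `CCOC(=O)c1ccc(Oc2ccc(F)c(F)c2)cc1O`: > 30000 nM
Compound 3 `COc1cccc(OC)c1Oc1ccc(C#N)cc1`: > 20000 nM

These three results come from a functional assay on HL-60 cells (Homo sapiens) for antiproliferative activity (a lower number here means a stronger inhibitor, a higher number a weaker inhibitor), and each is a limit rather than a number. Compound 3 stands at a limit, > 20000 nM. That places it at the limit of > 20000 nM in this assay, at which 2 of the 3 values shown sit. Among the compounds with values here, no measured pair here differs in one place, so the data give no size for a single change.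

Compound 4 `COc1cccc(OC)c1Oc1ccc(N(C)C)cc1` carries dimethylamino in place of cyano on an aromatic carbon, para to a large group: dimethylamino in place of cyano on an aromatic carbon. The step is expected to be small and toward stronger inhibition, with an estimated size of an at least 1.3-fold lower number from compound 3 to compound 4 (0.12 log units; that floor lies within the scatter). This expectation is uncertain, and the result may again be only a limit. Compound 4 is estimated at 15000 nM, with an expected range of 3000 nM to 40000 nM.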

Compound 4, half-maximal inhibitory concentration: 11400 nM
Estimate against measurement, compound 4: 1.3-fold (0.12 log units) above; the measured number falls inside the stated range.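

In this assay, within the data shown here, compound 4 gives 11400 nM, the only value in this set that is a number rather than a limit. Dimethylamino in place of cyano, on an aromatic carbon para to a large group, gives an at least 1.7-fold lower number from compound 3 to compound 4 (0.24 log units; that floor lies within the scatter), so the change can be read only as a floor. Compound 3 holds a limit, not a number: the limit of > 20000 nM in this assay, at which 2 of the 4 values shown sit. As far as these compounds go, the full size of this step stays open, as does whether a primary amine or a carboxylic acid in the same place would give a lower number than dimethylamino.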